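The source may hold more compounds than are shown below. What is called first, only, known or untested is meant among the compounds shown, and "the series" means these compounds.

Measured compounds, in an assay on membranes from lung (Cavia porcellus) for binding affinity to cysteinyl leukotriene receptor (Homo sapiens); on this read-out lower numbers stand for stronger inhibition and higher numbers for weaker inhibition: compound 1, `O=C(O)CCSC(SCCC(=O)O)c1ccccc1CCCCCCCCCCCC(F)(F)F`, gives 147 nM. Compound 3, `CCCCCCCCCCCCCOc1cccc(C(SCCC(=O)O)SCCC(=O)O)c1`, gives 530 nM. Compound 2, `CCOCCOCCOCCOc1ccccc1C(SCCC(=O)O)SCCC(=O)O`, gives only a limit of the assay, > 20000 nM.

Compound 3 holds the highest of the two numbers shown; the nearest number is that of compound 1, which is lower by a margin beyond the scatter. The value of compound 2 is a limit and no number, (the limit of > 20000 nM in this assay, at which 1 of the 3 values shown sits).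

Compound 4, `CCCCCCCCCOc1cccc(C(SCCC(=O)O)SCCC(=O)O)c1`, is still to be measured in this assay. It differs from compound 3 by hydrogen in place of butyl on a saturated chain carbon, nine bonds along the chain from an oxygen on an aromatic ring, so the chain at the ring oxygen is shortened. For the measured compounds named here, no pair of measured compounds differs in one place, so no measured step guides this change. Of the shown compounds, the two bearing long chains, compound 1 and compound 3, give numbers, while compound 2, with a different chain, sits at the limit. The number for compound 4 is therefore expected to rise, by an estimated step of a 2.8-fold higher number from compound 3 to compound 4 (0.45 log units; beyond the scatter). Compound 4 is estimated at 1500 nM, in a range from 400 nM to 6000 nM.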

Compound 4, inhibition constant: 624 nM
Beside the measured number, compound 4's estimate is 2.4-fold (0.38 log units) above it, within the range that was stated.
By their numbers in this assay, from the lowest: compound 1; then compounds 3 and 4 (each within the scatter of the next). At a limit, above all of these: compound 2.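

For the compounds shown here, this is the first single-place step: hydrogen in place of butyl on a saturated chain carbon, nine bonds along the chain from an oxygen on an aromatic ring, gives a 1.2-fold higher number from compound 3 to compound 4 (0.07 log units; within the scatter) in this assay. On this read-out, the chain at the ring oxygen can therefore lose butyl at this place without a difference that can be told from the scatter, so compound 3 and compound 4 cannot be separated. No measured property in hand bears on this step.

From the compounds shown here alone, it stays open how far the chain at the ring oxygen can be cut beyond compound 4 before the number moves beyond the scatter. Also open, going by these compounds, is whether a longer chain or an amine in that chain would give a number in this range.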